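Pyridinyl amide replaces methoxyphenyl amide in a weak series

The compounds below may be only part of what the source reports. "The series", "measured", "known", "first", "only" and "open" are said of these compounds alone.

Three compounds share a common core. Compound 1 `COc1ccc(C(=O)Nc2ccc(Cl)cn2)cc1Nc1nccc(-c2cccnc2)n1` and compound 2 `COc1ccc(C(=O)Nc2nccs2)cc1Nc1nccc(-c2cccnc2)n1` carry different amide partners on that core. In a functional assay on K562 cells (Homo sapiens) for antiproliferative activity, read by MTT assay, with a stated time of 48 h (a higher number here means a weaker inhibitor, a lower number a stronger inhibitor), compound 1 gives "not determined" (no result reported). In this assay compound 2 gives "not determined" (no result reported). Only compound 3 `COc1cccc(NC(=O)c2ccc(OC)c(Nc3nccc(-c4cccnc4)n3)c2)c1` has a number: in this assay compound 3 gives 93100 nM, a very weak result and the only one to which anything else can be compared.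

Compound 4 `COc1ccc(C(=O)Nc2ccncc2)cc1Nc1nccc(-c2cccnc2)n1` is the next step. It differs from compound 3 in a single place: pyridin-4-yl in place of 3-methoxyphenyl on an amide-type nitrogen. Among the compounds with values here, no measured pair in this set shows what such a swap does, so there is no comparison to lean on. The step of a 1.3-fold lower number from compound 3 to compound 4 (0.12 log units; within the scatter) is expected to stay close to the scatter of this assay, with the direction left open. The estimate for compound 4 in this assay is therefore 70000 nM, expected to lie between 15000 nM and 250000 nM, and with a real chance that only a limit rather than a number is reported.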

Compound 4, half-maximal inhibitory concentration: 94500 nM
Beside the measured number, compound 4's estimate is 1.4-fold (0.13 log units) below it, within the range that was stated.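

In this assay, pyridin-4-yl in place of 3-methoxyphenyl on an amide-type nitrogen gives a 1.0-fold higher number from compound 3 to compound 4 (0.01 log units; within the scatter), so compound 3 and compound 4 cannot be told apart. Within the data shown here, this is the only readable pair, and it shows that, at this place, a six-membered aromatic ring with one hetero atom and a smaller heavy-atom count reads the same as the carbon-only ring with its methoxy group, with both compounds remaining very weak. Nothing shown bears on why this swap leaves the number where it stands.

Compound 1 and compound 2 carry no number, so steps to them cannot be read. On these data alone, it remains open whether a non-aromatic amide partner, such as a piperidine or a short chain ending in a carboxylic acid, would move the number at this place beyond the scatter.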